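The compounds below may be only part of what the source reports. "The series", "measured", "known", "first", "only" and "open" are said of these compounds alone.

Measured compounds in an ADME assay on microsomes from liver (Rattus norvegicus, strain Sprague-Dawley) for metabolic stability, read by LC-MS, using NADPH, with a stated time of 30 min, tested at 1 uM; on this read-out lower numbers stand for a less stable compound and higher numbers for a more stable compound:
- compound 1 `O=C(C[C@H](CCN1CCCCC1)NC(=O)c1cc(-c2ccccc2Cl)n(C2CCCC2)n1)NC1CCC1`: "nd" (no result reported) (no result reported)
- compound 2 `COc1cccc(F)c1-c1cc(C(=O)N[C@@H](CCN2CCCCC2)CC(=O)NC2CCC2)nn1C1CCCC1`: 74.3%
- compound 3 `O=C(C[C@H](CCN1CCCCC1)NC(=O)c1cc(-c2cccc[n+]2[O-])n(C2CCCC2)n1)NC1CCC1`: "nd" (no result reported) (no result reported)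

Compound 3 stands without a number of its own; it shares this with compound 1, which likewise carries no reported result. Among the compounds with values here, only compound 2 supplies a figure in this assay, and it is a single point, so no step between measured compounds can be drawn and no trend can be claimed from it.

Compound 4 `O=C(C[C@H](CCN1CCCCC1)NC(=O)c1cc(-c2ccccc2C2CC2)n(C2CCCC2)n1)NC1CCC1` differs from compound 3 in one place: a group of 9 heavy atoms (9 carbon; one three-membered non-aromatic ring of carbon only, one six-membered aromatic ring of carbon only) in place of a group of 7 heavy atoms (5 carbon, 1 nitrogen, 1 oxygen; one six-membered aromatic ring with 1 hetero atom), on an aromatic carbon

Within the data shown here, since no measured pair in this set shares a comparable change, the size of the step from compound 3 to compound 4 in this assay cannot be read from the data, and no direction for it is known; it could lie within the scatter or well beyond it. Among the measured compounds shown here, the only anchor is compound 2 with its value of 74.3% on the same shared core with a different aromatic group.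

For compound 4 the estimated remaining fraction in this assay is 55%, with an expected range from 25% to 85%.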

Compound 4, percent of the compound remaining: 70.1%
Compound 4: the middle estimate sits 15.1 percentage points below what was measured; the range from low to high includes it.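

Compound 4 gives the study its first comparison at the aromatic carbon next to the ring atom that bears a cyclopentyl group. In this assay, putting 2-cyclopropylphenyl in place of 2-fluoro-6-methoxyphenyl gives a number 4.2 percentage points lower from compound 2 to compound 4 (within the scatter), so this read-out does not separate these two groups, although one is built of carbon alone and the other is not. Nothing available explains this result, and the comparison rests on this single pair of compounds.

Within the data shown here, compound 1 and compound 3 have no reported result, so no step involving either of them can be read, and the 2-chlorophenyl group and the six-membered aromatic ring with one hetero atom remain unplaced against the two groups that have values. As far as these compounds go, it also stays open whether the same read-out would hold for a phenyl ring carrying a carboxylic acid or an amine at this position, or for a compound in which the cyclopentyl group or the cyclobutyl amide is replaced.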